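A Nitro Group Added to Compound 2: What to Expect

This account rests on a few compounds, and the source may have more. Where it says the series, first, only, none or still open, it means among the compounds named here.

Compounds measured in a functional assay on CCRF-CEM cells (Homo sapiens) for antiproliferative activity, with a stated time of 72 h; a lower number here means a stronger inhibitor, a higher number a weaker inhibitor:
compound 1, `COc1ccc(-c2csc(=N)n2-c2ccc(OC)cc2)cc1`, gives > 20000 nM, which is a limit of the assay.
compound 2, `COc1ccc(-n2c(-c3cc(OC)c(OC)c(OC)c3)c(Cl)sc2=O)cc1`, gives 13800 nM.
compound 3, `COc1ccc(-c2c(Cl)sc(=O)n2-c2cc(OC)c(OC)c(OC)c2)cc1`, gives > 20000 nM, which is a limit of the assay.

Going by the values given here, compound 2 is the only member of this small set with a measured number in this assay, and that number is itself weak. The rest sits at the limit of > 20000 nM in this assay, at which 2 of the 3 values shown sit. Among the compounds with values here, there is no pair of measured compounds that differ in a single place, so no measured step tells how a single change shifts the read-out here.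

Compound 4, `COc1ccc(-n2c(-c3cc(OC)c(OC)c(OC)c3)c(Cl)sc2=O)cc1[N+](=O)[O-]`, has not yet been tested. It differs from compound 2 by nitro in place of hydrogen on an aromatic carbon.

Within the data shown here, with no measured step to lean on, the expectation for compound 4 rests only on the weak standing of compound 2 and on the change itself. The estimated step from compound 2 to compound 4 in this assay is a 1.2-fold lower number from compound 2 to compound 4 (0.06 log units; within the scatter), a shift not clearly beyond the scatter and as likely to land at the assay limit as to yield a number. Compound 4 is therefore expected to give about 12000 nM, within a range from 3500 nM to 40000 nM.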

Compound 4, half-maximal inhibitory concentration: > 20000 nM
Compound 4 was reported as a limit (the forecaster's own chance of this, stated with the estimate: 40%); middle value at least 1.6-fold (0.22 log units) from the limit.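

In this assay, the set now holds its first measured change in a single place: nitro in place of hydrogen on an aromatic carbon, ortho to a methoxy group, gives an at least 1.4-fold higher number from compound 2 to compound 4 (0.16 log units; that floor lies within the scatter). This step is a floor and not a size, so the true shift may lie within the usual scatter or may be much larger, and the result cannot separate these two cases. It does show that this change at this position yields no measured number, which leaves compound 2 as the only compound in the set with one, while the rest stay at the limit: the limit of > 20000 nM in this assay, at which 3 of the 4 values shown sit.

As far as these compounds go, whether the outcome belongs to nitro or to the position remains open, and an amine or a hydroxyl group at the same aromatic carbon would help to separate the two. From the compounds shown here alone, with a single measured number to work from, it also remains open whether any change to compound 2 can bring a clearly lower number in this assay.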